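Selenium Gives Way to Cyanosulfanyl in Compound 4

The compounds below may be only part of what the source reports. "The series", "measured", "known", "first", "only" and "open" are said of these compounds alone.

Within the data shown here, compound 3 `O=C1c2ccccc2C(=O)N1C[SeH]` is the only member of this set with a number: in a functional assay on MCF7 cells (Homo sapiens) for cytotoxicity, read by MTT assay, with a stated time of 72 h (a lower number here means a stronger inhibitor of growth, a higher number a weaker inhibitor of growth), compound 3 gives 6000 nM. Compound 1 `Sc1ccnc(S)n1` reaches only the limit of > 100000 nM. Compound 2 `O=C1c2ccccc2C(=O)N1CS` likewise stops at the limit of > 100000 nM. Among the measured compounds shown here, the single measured step, an at least 16-fold lower number from compound 2 to compound 3 (1.22 log units; beyond the scatter), rests on (the limit of > 100000 nM in this assay, at which 2 of the 3 values shown sit), so only its minimum size is known. Compound 4 `N#CSCN1C(=O)c2ccccc2C1=O` differs from compound 3 by a group of 3 heavy atoms (1 carbon, 1 nitrogen, 1 sulfur; no ring) in place of one selenium atom, on a saturated chain carbon bound to an amide-type nitrogen in a ring. The sulfur that returns here is the atom whose replacement by selenium produced that measured step, so the step from compound 3 to compound 4 is expected to run toward a higher number, quite possibly back to a limit. Compound 4 is therefore estimated at 60000 nM, within 10000 nM to 300000 nM, an expected 10-fold higher number from compound 3 to compound 4 (1.00 log units; beyond the scatter).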

Compound 4, concentration for 50% growth inhibition: 48100 nM
Compound 4: middle estimate off by 1.2-fold (0.10 log units), on the high side; low and high end bracket the measured number.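

In this assay, cyanosulfanyl on this saturated chain carbon does not match the selenium of compound 3, with an 8.0-fold higher number from compound 3 to compound 4 (0.90 log units; beyond the scatter). The sulfur compounds do differ from one another, however: cyano in place of hydrogen on a sulfur gives an at least 2.0-fold lower number from compound 2 to compound 4 (0.31 log units; beyond the scatter). Only the minimum size of that second step is known: the limit of > 100000 nM in this assay, at which 2 of the 4 values shown sit.

Still open, from the compounds shown here alone, is whether a selenium atom carrying cyano would combine the two changes. Going by these compounds, it is also open whether a methyl group or a longer chain on the sulfur would act as cyano does.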